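The source may report more compounds than this note shows. Statements on the series, on what has been measured and on what is new or still open speak of the compounds shown alone.

Within the data shown here, compound 1, `Cc1c(C(=O)O)oc2ccc(N(Cc3ccccc3)S(=O)(=O)c3ccc(Br)cc3)cc12`, is the only compound of this set for which a number rather than a limit is known: in a functional assay on HCT-116 cells (Homo sapiens) for inhibition, read by MTT assay, with a stated time of 72 h (a lower number here means a stronger inhibitor, a higher number a weaker inhibitor), compound 1 gives 20000 nM. Compound 2, `Cc1c(C(=O)O)oc2ccc(N(Cc3ccc(Br)cc3)S(=O)(=O)c3ccc(Br)cc3)cc12`, carries a bromo in place of a hydrogen on an aromatic carbon of the benzyl group. In this assay compound 2 reaches only a limit of the measurement, > 40000 nM. The step of an at least 2.0-fold higher number from compound 1 to compound 2 (0.30 log units; that floor lies within the scatter) therefore cannot be sized beyond its floor, and it rests on (the limit of > 40000 nM in this assay, at which 1 of the 2 values shown sits).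

Compound 3, `Cc1c(C(=O)O)oc2ccc(N(Cc3ccccc3)S(=O)(=O)c3ccc(C(F)(F)F)cc3)cc12`, differs from compound 1 by trifluoromethyl in place of bromo on an aromatic carbon. Among the measured compounds shown here, no measured step touches this position: the one step that is known, from compound 1 to compound 2, alters the benzyl group and leaves the sulfonyl-bound ring untouched, so it offers no direct guide. With no evidence of a change in this assay, the expectation for compound 3 is a step of no change at the digits printed from compound 1 to compound 3 (within the scatter), that is, no shift beyond the usual scatter of this assay. Compound 3 is thus estimated at 20000 nM, within a range from 8000 nM to 50000 nM.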

Compound 3, half-maximal inhibitory concentration: 21100 nM
Compound 3: middle estimate off by 1.1-fold (0.02 log units), on the low side; low and high end bracket the measured number.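

Trifluoromethyl in place of bromo, on an aromatic carbon of a six-membered aromatic ring of carbon only and para to a large group, gives the first reading at this position: in this assay the change from 4-bromophenyl to 4-(trifluoromethyl)phenyl is a 1.1-fold higher number from compound 1 to compound 3 (0.02 log units; within the scatter). Unlike the earlier step on the benzyl group, this one has a number at both ends, so its size can be read in full, and it shows that these two groups cannot be told apart at this position in this assay, even though the group that enters has more heavy atoms than the one that leaves. Nothing shown here offers a cause for this outcome.

The compounds shown leave open whether a different group at this position, such as an amine, a nitrile or a carboxylic acid, would give a number that stands apart from these two. As far as these compounds go, compound 2 remains a limit, > 40000 nM, so it also remains open how a bromo on the benzyl group would read alongside trifluoromethyl at this position.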